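The source may hold more compounds than are shown below. What is called first, only, known or untested is meant among the compounds shown, and "the series" means these compounds.

Measured so far:
compound 1 `CSc1cnc2ccccc2c1[Se]CC#CCCl` — 3.5 ug/mL
compound 2 `CCOC(=O)OCC#CCSc1c(SC)cnc2ccccc12` — 5.5 ug/mL
compound 3 `CSc1cnc2ccccc2c1SCC#CCOC(=O)c1ccc(C(=O)O)cc1` — 18.1 ug/mL

In a functional assay on B16 cells (Mus musculus) for antiproliferative activity, with a stated time of 72 h (on this read-out lower numbers stand for stronger inhibition and higher numbers for weaker inhibition), compound 2 sits second highest of the three numbers, close to compound 1 and further from compound 3. Compound 4 `CSc1cnc2ccccc2c1SCC#CCCl` is not yet measured; it differs from compound 2 by chloro in place of (ethoxycarbonyl)oxy on a saturated chain carbon bound to a triple-bonded carbon. Among the measured compounds shown here, the only measured step, a 3.3-fold higher number from compound 2 to compound 3 (0.52 log units; beyond the scatter), alters the carbonyl substituent and not the whole group, so it bears on this change only loosely. Compound 1 carries the same chloro group and gives 3.5 ug/mL, which suggests compound 4 could land near it. The step is therefore expected to be small, a 1.6-fold lower number from compound 2 to compound 4 (0.20 log units; within the scatter), toward a lower number, and compound 4 is estimated at 3.5 ug/mL (range 1.5 ug/mL to 8 ug/mL).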

Compound 4, concentration for 50% inhibition: 16.9 ug/mL
For compound 4 the middle estimate is 4.8-fold (0.68 log units) below the measured one, and the stated range ends below it.
By their numbers in this assay, from the lowest: compounds 1 and 2 (each within the scatter of the next); then compounds 4 and 3 (each within the scatter of the next).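

In this assay, chloro on a saturated chain carbon bound to a triple-bonded carbon proves no gain over (ethoxycarbonyl)oxy: that change gives a 3.1-fold higher number from compound 2 to compound 4 (0.49 log units; beyond the scatter) and so weakens inhibition. Chloro alone also does not secure a low number, since sulfur in place of selenium in the group on an aromatic carbon gives a 4.8-fold higher number from compound 1 to compound 4 (0.68 log units; beyond the scatter) while chloro stays in place. Nothing shown here explains either step.

On these data alone, an amine or a hydroxyl at this chain position remains open. So does whether selenium would lower the number with (ethoxycarbonyl)oxy in place of chloro.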